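The source may hold more compounds than are shown below. What is called first, only, known or untested is meant among the compounds shown, and "the series" means these compounds.

In an ADME assay on microsomes from liver (Mus musculus) for metabolic stability, read by LC-MS, using NADPH, with stated times of 5 min and 30 min, at 37 degrees C (on this read-out lower numbers stand for a shorter-lived compound and higher numbers for a longer-lived compound), compound 1 `C[C@H](O)[C@@H](CCc1ccc(C(F)(F)F)cc1)n1cnc2c(N)ncnc21` gives > 0.5 h, a limit of the assay and not a number. Compound 2 `C[C@H](O)[C@@H](CCc1cccc(-c2nccs2)c1)n1cnc2c(N)ncnc21` gives > 0.5 h, which is likewise only a limit. The two compounds therefore share (the limit of > 0.5 h in this assay, at which 2 of the 2 values shown sit), and neither can be ordered against the other. Compound 3 `CNC(=O)c1cccc(CC[C@H]([C@H](C)O)n2cnc3c(N)ncnc32)c1` carries methylcarbamoyl in place of 1,3-thiazol-2-yl on an aromatic carbon, meta to a large group: methylcarbamoyl in place of 1,3-thiazol-2-yl on an aromatic carbon. For the measured compounds named here, no measured step is available to size this change. In this assay the expected step is a step that the limit leaves unreadable from compound 2 to compound 3, with no direction and nothing beyond the scatter anticipated. Compound 3 is estimated at 0.6 h, with an expected range of 0.3 h to 1.2 h.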

Compound 3, half-life: > 0.5 h
Compound 3 ended at the assay's limit; the forecaster's own chance of this, stated with the estimate: 75%; the middle value is on the limit's open side.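

Compound 3, like compound 2, sits at a limit of this assay, so no step from compound 2 to compound 3 can be read: the limit of > 0.5 h in this assay, at which 3 of the 3 values shown sit.

From the compounds shown here alone, the actual half-lives of compound 1, compound 2 and compound 3 stay open, and so does any effect of methylcarbamoyl in place of 1,3-thiazol-2-yl.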